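This account rests on a few compounds, and the source may have more. Where it says the series, first, only, none or still open, it means among the compounds named here.

In a functional assay on the whole organism (strain Wistar) for inhibition, with Rattus norvegicus as the target, read by paw edema, with stated times of 30 min and 3 h, at a dose of 100 mg/kg by the oral route (on this read-out higher numbers stand for a stronger effect at the one dose given and lower numbers for a weaker effect), compound 1 `Cn1ncc(O)c(Cl)c1=O` gives -5.8%, compound 2 `CCOc1c(NC)cnn(C)c1=O` gives 31.1%, and compound 3 `CCCNc1cnn(C)c(=O)c1OCC` gives 38%. On the numbers shown compound 3 stands highest, but the step of a number 6.9 percentage points higher from compound 2 to compound 3 (within the scatter) is within the scatter, so compound 2 and compound 3 cannot be told apart; only compound 1 lies clearly lower than compound 3.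

Compound 4 `CCOc1c(N(CC)CC)cnn(C)c1=O` differs from compound 3 in one place: diethylamino in place of propylamino on an aromatic carbon. Going by the values given here, the only measured step that touches the same region of the shared core is a number 6.9 percentage points higher from compound 2 to compound 3 (within the scatter), where a larger chain on the nitrogen bound to the ring brought no change beyond the scatter. On that basis the move to a diethylamino group is expected to give a step of roughly a number 3 percentage points lower from compound 3 to compound 4 (within the scatter) in this assay, which is no change beyond the scatter. Compound 4 is therefore estimated at 35%, with a range from 15% to 55%.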

Compound 4, a percentage reported as inhibition, in the whole organism at one dose (the size of the read-out at that dose, not a potency): 32.5%
Compound 4: middle estimate off by 2.5 percentage points, on the high side, and the stated range covers the measured number.
By their numbers in this assay, from the lowest: compound 1; then compounds 2, 4 and 3 (each within the scatter of the next).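

In this assay, diethylamino in place of propylamino on this aromatic carbon gives a number 5.5 percentage points lower from compound 3 to compound 4 (within the scatter) and diethylamino in place of methylamino gives a number 1.4 percentage points higher from compound 2 to compound 4 (within the scatter), so compounds 2, 3 and 4 cannot be told apart. The new point is that a second chain on the nitrogen bound to the ring, with the hydrogen-bond donor of propylamino gone, still leaves the read-out within the scatter of the compounds that keep that hydrogen. No measurement at hand explains this result.

Still open, as far as these compounds go, is whether a cyclic amine such as morpholine, or a longer chain such as butylamino, on this carbon would move the number beyond the scatter. Also open, from the compounds shown here alone, is what a methoxy or a hydroxyl group in place of the ethoxy group would do.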